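The source may hold more compounds than are shown below. What is called first, only, known or untested is meant among the compounds shown, and "the series" means these compounds.

Two compounds of the series have numbers in an assay on isolated protein for inhibition of Rho-associated protein kinase 1 (Homo sapiens), read by radiometric assay and 33P incorporation, with a stated time of 40 min, in the presence of a further agent that is not named here (on this read-out lower numbers stand for stronger inhibition and higher numbers for weaker inhibition), so far. Compound 1 `COc1cccc(Cn2cnc3sc(-c4ccnc(F)c4)cc3c2=O)c1` gives 1050 nM in this assay. For the measured compounds named here, compound 2 `COc1cccc(Cn2cnc3sc(-c4ccnc(N)c4)cc3c2=O)c1` gives 18 nM in this assay, the lowest of the two numbers; the step of a 58-fold lower number from compound 1 to compound 2 (1.77 log units; beyond the scatter) is the only measured step in the set, and it concerns the exchange of fluoro for amino on the ring carbon, not a change in how the ring is attached.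

Compound 3 `COc1cccc(Cn2cnc3sc(-c4ccc(N)nc4)cc3c2=O)c1` differs from compound 2 by 6-aminopyridin-3-yl in place of 2-aminopyridin-4-yl on an aromatic carbon. Going by the values given here, this is a rearrangement of the same atoms rather than an addition or removal of a group, and no measured step bears on it directly; the step from compound 1 to compound 2 shows only that the amino group matters a great deal where it is, not what happens when the ring is joined differently. Among the compounds with values here, with no guiding step, a move to a higher number is taken as the more likely outcome, with wide uncertainty in both directions.

For compound 3 the value in this assay is estimated at 70 nM, with a range from 12 nM to 450 nM; this corresponds to an expected step of a 3.9-fold higher number from compound 2 to compound 3 (0.59 log units; beyond the scatter).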

Compound 3, half-maximal inhibitory concentration: > 10000 nM
Compound 3: only a limit was reported (the forecaster's own chance of this, stated with the estimate: 3%); middle value at least 140-fold (2.15 log units) away from the limit.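

In this assay compound 3 carries a limit of the assay and not a number: the limit of > 10000 nM in this assay, at which 1 of the 3 values shown sits. At this place, on an aromatic carbon next to the ring sulfur, having an aminopyridine is therefore not enough: the exchange of 2-aminopyridin-4-yl for 6-aminopyridin-3-yl, with the same atoms joined differently, gives an at least 550-fold higher number from compound 2 to compound 3 (2.74 log units; beyond the scatter). The arrangement of the ring also outweighs the presence of the amino group in this pair, as 6-aminopyridin-3-yl against 2-fluoropyridin-4-yl gives an at least 9.5-fold higher number from compound 1 to compound 3 (0.97 log units; beyond the scatter), so the fluoro compound, weak as it is, still ranks ahead of the aminated isomer.

In the compounds shown, the ring nitrogen and the amino group shift together, so the loss cannot be assigned to either one alone, and the true size of both new steps remains unread behind the limit. Also open, on these data alone, is how far the 2-aminopyridin-4-yl group tolerates change at the amino group itself, for example a methylamino group, an acetamide or a hydroxyl in its place.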